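Cyclohexyl to heptyl on the ether oxygen of the series

The source may hold more compounds than are shown below. What is called first, only, known or untested is meant among the compounds shown, and "the series" means these compounds.

Measured compounds:
compound 1, `CCCOCNc1n[n+]([O-])c2cc(OC)ccc2[n+]1[O-]`, 6570 nM
compound 2, `[O-][n+]1nc(NCOCc2ccc(C(F)(F)F)cc2)[n+]([O-])c2ccccc21`, 7650 nM
compound 3, `[O-][n+]1nc(NCOC2CCCCC2)[n+]([O-])c2ccccc21`, 3250 nM

Three compounds of the shared core carry an amino-methylene-ether arm and have been run in a functional assay on PC-3 cells (Homo sapiens) for cytotoxicity, read by MTT assay, with a stated time of 72 h; a higher number here means a weaker inhibitor, a lower number a stronger inhibitor. Compound 3 gives the lowest number of the three. Its nearest neighbour is compound 1, whose value lies beyond the scatter from it, and compound 2 sits furthest away, also beyond the scatter. On these three numbers compound 3 is therefore the strongest inhibitor of the set.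

Compound 4, `CCCCCCCOCNc1n[n+]([O-])c2ccccc2[n+]1[O-]`, has not yet been measured. It differs from compound 3 in one place: heptyl in place of cyclohexyl on an oxygen on a saturated carbon. In words, heptyl in place of cyclohexyl on an oxygen on a saturated carbon. Among the measured compounds shown here, no measured pair shows such a ring-to-chain exchange on the ether oxygen, so no step can be read off directly; the expectation rests on compound 3 alone.

The step from compound 3 to compound 4 is expected to be small, at most a modest weakening, as a 1.3-fold higher number from compound 3 to compound 4 (0.11 log units; within the scatter). Compound 4 is accordingly estimated at 4200 nM, within a range from 1800 nM to 9500 nM.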

Compound 4, half-maximal inhibitory concentration: 1210 nM
Compound 4: middle estimate off by 3.5-fold (0.54 log units), on the high side; measured number outside the range, below it.
By their numbers in this assay, from the lowest: compound 4; then compound 3; then compounds 1 and 2 (each within the scatter of the next).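

In this assay, the oxygen on a saturated carbon proves to be a position where the group matters: heptyl in place of cyclohexyl gives a 2.7-fold lower number from compound 3 to compound 4 (0.43 log units; beyond the scatter), a modest step beyond the scatter and towards stronger inhibition. Among the compounds shown here, this is the first step that can be read between compounds differing in one place, as the earlier compounds offered only separate values. It shows that, on the shared core, the cyclohexyl ring is not required for this level of cytotoxicity and that an open chain can take its place with a gain; nothing measured on these compounds accounts for that gain.

The change removes a ring and raises the carbon count together, so this single pair cannot separate the two, and a hexyl chain or a longer chain such as decyl would be needed to tell how far the trend with chain length runs. Also open, from the compounds shown here alone, are whether a branched chain or a terminal amine or carboxylic acid on the heptyl chain would keep the step, and whether heptyl has the same effect on the core of compound 1.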